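Aryl swap on the ethynyl arm: thiazolyl for dimethylfuranyl

The compounds below may be only part of what the source reports. "The series", "measured", "known", "first", "only" and "open" are said of these compounds alone.

Measured so far in an assay on CHO cells for displacement of a labelled ligand from adenosine receptor A1 (Homo sapiens), read by scintillation counting, with a stated time of 60 min, tested at 10 uM; on this read-out higher numbers stand for more inhibition at the one concentration tested (going by the name of the read-out) and lower numbers for less inhibition:
compound 1 `CNC(=O)[C@@]12C[C@@H]1[C@@H](n1cnc3c(NC)nc(C#Cc4ccc(F)cc4)nc31)[C@H](O)[C@@H]2O` — 27%
compound 2 `CNC(=O)[C@@]12C[C@@H]1[C@@H](n1cnc3c(NC)nc(C#Cc4ncccn4)nc31)[C@H](O)[C@@H]2O` — 25%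
compound 3 `CNC(=O)[C@@]12C[C@@H]1[C@@H](n1cnc3c(NC)nc(C#Cc4cc(C)c(C)o4)nc31)[C@H](O)[C@@H]2O` — 15%

Compound 3 carries the lowest of the three numbers, but only its gap to compound 1 is beyond the scatter: a number 12 percentage points lower from compound 1 to compound 3 (beyond the scatter), whereas a number 10 percentage points lower from compound 2 to compound 3 (within the scatter) and a number 2 percentage points lower from compound 1 to compound 2 (within the scatter). The next compound, compound 4 `CNC(=O)[C@@]12C[C@@H]1[C@@H](n1cnc3c(NC)nc(C#Cc4nccs4)nc31)[C@H](O)[C@@H]2O`, differs from compound 3 only on the triple-bonded carbon: 1,3-thiazol-2-yl in place of 4,5-dimethylfuran-2-yl on a triple-bonded carbon. For the measured compounds named here, all three steps so far exchange the group on that same carbon, and two of them stay within the scatter, so the exchange here is expected to move the number little, if at all, and if anything back toward the values of compound 1 and compound 2. Compound 4 is therefore estimated at 22% in this assay, between 10% and 35%, an expected change of a number 7 percentage points higher from compound 3 to compound 4 (within the scatter).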

Compound 4, a percentage reported as inhibition, at one concentration (the size of the read-out at that concentration, not a potency): 31%
The estimate for compound 4 lay 9 percentage points below the measured number; low and high end bracket the measured number.
By their numbers in this assay, from the lowest: compounds 3, 2, 1 and 4 (each within the scatter of the next, the first and the last beyond it).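

In this assay, the exchange on the triple-bonded carbon gives a number 16 percentage points higher from compound 3 to compound 4 (beyond the scatter), so a five-membered aromatic ring at this position does not by itself go with the low number of compound 3. The 1,3-thiazol-2-yl group stays level with pyrimidin-2-yl and 4-fluorophenyl, with a number 6 percentage points higher from compound 2 to compound 4 (within the scatter) and a number 4 percentage points higher from compound 1 to compound 4 (within the scatter). Nothing available explains the gap between the two five-membered rings.

Open, from the compounds shown here alone, is whether the methyl groups of 4,5-dimethylfuran-2-yl or its ring oxygen go with the lower number, which an unsubstituted furan-2-yl would help separate. Also open, going by these compounds, is how an amine or carboxylic acid on the thiazolyl ring would read.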